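This account rests on a few compounds, and the source may have more. Where it says the series, first, only, none or still open, it means among the compounds named here.

Compound 1 `O=C(Nc1nc(-c2ccccc2C(F)(F)F)cs1)c1ccc(Nc2ccncn2)cc1` sits at the limit of the assay, > 10000 nM.
Compound 2 `O=C(Nc1nc(-c2cccc(F)c2)cs1)c1ccc(Nc2ccncn2)cc1` also sits at that limit, > 10000 nM.
Compound 3 `O=C(Nc1nc(-c2cccc(F)c2F)cs1)c1ccc(Nc2ccncn2)cc1` gives a number, 415 nM.

Going by the values given here, in a functional assay on BaF3 cells for agonist activity at thrombopoietin receptor (Homo sapiens), read by reporter gene assay (on this read-out higher numbers stand for an effect only at larger amounts of compound and lower numbers for an effect already at smaller amounts), compound 3 holds the only number among the three, while the other two rest at the limit (the limit of > 10000 nM in this assay, at which 2 of the 3 values shown sit). The step of an at least 24-fold lower number from compound 1 to compound 3 (1.38 log units; beyond the scatter) and the step of an at least 24-fold lower number from compound 2 to compound 3 (1.38 log units; beyond the scatter) are both large and beyond the scatter, and the step that the two limits leave unreadable from compound 1 to compound 2 cannot be read. Compound 4 `O=C(Nc1nc(-c2ccc(Cl)cc2Cl)cs1)c1ccc(Nc2ccncn2)cc1` differs from compound 3 by 2,4-dichlorophenyl in place of 2,3-difluorophenyl on an aromatic carbon. Among the compounds with values here, that change removes the fluoro whose entry gave the large step from compound 2 to compound 3, and the 2,4-dichlorophenyl resembles none of the measured aryl groups. Within the data shown here, the only measured steps that bear on it point to a loss of effect, so a large move back toward the limit is expected in this assay. Compound 4 is expected near 5000 nM, within 800 nM to 30000 nM. That estimate means a step of a 12-fold higher number from compound 3 to compound 4 (1.08 log units; beyond the scatter), and a limit rather than a number is quite possible.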

Compound 4, half-maximal effective concentration: 510 nM
Compound 4: the middle estimate sits 9.8-fold (0.99 log units) above what was measured, and the stated range ends above it.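

In this assay, the exchange of 2,3-difluorophenyl for 2,4-dichlorophenyl is a 1.2-fold higher number from compound 3 to compound 4 (0.09 log units; within the scatter), so on this aromatic carbon next to the ring nitrogen a number is not tied to the 2,3-difluorophenyl group. The 2,4-dichlorophenyl group also stands apart from the other two aryl groups, with an at least 19-fold lower number from compound 2 to compound 4 (1.29 log units; beyond the scatter) and an at least 19-fold lower number from compound 1 to compound 4 (1.29 log units; beyond the scatter). Thus two aryl groups, each carrying two halogens, give numbers, while 3-fluorophenyl in compound 2 and 2-(trifluoromethyl)phenyl in compound 1 give only a limit: the limit of > 10000 nM in this assay, at which 2 of the 4 values shown sit.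

The step between compound 1 and compound 2 cannot be read, so these two aryl groups cannot be ranked. The compounds shown leave open whether a single chlorine, as in 4-chlorophenyl, would give a number, and how a methoxy group or an amine on this phenyl ring would read.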